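A few compounds are considered here, and "the series" means these few. Any claim that something is new, unique, unknown or untested is made for them only; others in the source may bear on it.

Measured so far:
- Compound 1, `O=c1nc(N2CC[C@H](c3ccccc3)[C@@H](O)C2)sc2c([N+](=O)[O-])cc(C(F)(F)F)cc12`: 0.875 h
- Compound 2, `O=c1nc(N2CCN(Cc3ccc(OC(F)(F)F)cc3)CC2)sc2c([N+](=O)[O-])cc(C(F)(F)F)cc12`: 0.727 h

Both compounds were run in an ADME assay on microsomes from liver (Homo sapiens) for metabolic stability, with a stated time of 90 min, tested at 20 uM; a lower number here means that the compound disappears faster, a higher number that the compound lasts longer. Compound 1 gives 0.875 h, and compound 2 gives 0.727 h. Compound 2 holds the lower of the two numbers, but the gap to compound 1 lies within the usual scatter of this assay, so the two cannot be told apart on this evidence; they behave as a pair of similar results.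

Compound 3, `CN(C(=O)CN1CCN(c2nc(=O)c3cc(C(F)(F)F)cc([N+](=O)[O-])c3s2)CC1)c1ccccc1`, has not yet been tested. It differs from compound 2 in one place: methyl(phenyl)carbamoyl in place of 4-(trifluoromethoxy)phenyl on a saturated chain carbon bound to an amine nitrogen in a ring. The shared core and the ring amine remain as they are in compound 2.

For the measured compounds named here, no pair of measured compounds shows what this kind of exchange does in this assay, so there is no measured step to lean on. Only the two numbers above are available, and they sit close together. The expectation for compound 3 is therefore a step of a 1.0-fold lower number from compound 2 to compound 3 (0.02 log units; within the scatter), that is, no change beyond the scatter in either direction. Compound 3 is estimated to give 0.7 h, with a range from 0.35 h to 1.4 h.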

Compound 3, half-life: 1.48 h
Estimate against measurement, compound 3: 2.1-fold (0.33 log units) below, outside the stated range (above it).
By their numbers in this assay, from the lowest: compounds 2, 1 and 3 (each within the scatter of the next, the first and the last beyond it).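

In this assay, for the compounds shown here, the place on a saturated chain carbon bound to an amine nitrogen in a ring proves sensitive to what it carries: methyl(phenyl)carbamoyl in place of 4-(trifluoromethoxy)phenyl gives a 2.0-fold higher number from compound 2 to compound 3 (0.31 log units; beyond the scatter), the only step so far that can be read, and a modest one. The two groups are alike in several counted features, as each holds one six-membered aromatic ring of carbon only and one hydrogen-bond acceptor, so the number can move even when those features stay the same. Nothing measured here accounts for the step, so its cause remains unknown.

As far as these compounds go, with a single step, it remains open which part of the entering group goes with the longer half-life: the carbonyl, the methyl or the phenyl ring. Open as well is how this place would respond to other groups, such as a plain benzyl without the trifluoromethoxy, an amide with the amide hydrogen in place of the methyl, or a carboxylic acid, and whether the step would carry over to another core.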